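A few compounds are considered here, and "the series" means these few. Any claim that something is new, unique, unknown or untested is made for them only; others in the source may bear on it.

In a functional assay on CHO cells with adenosine receptor A1 (Homo sapiens) as the target, read by cAMP accumulation and immunoassay, with a stated time of 6 min, tested at 10 uM (a lower number here means a stronger effect, a higher number a weaker effect of the compound at the concentration tested), three compounds have been measured so far:
compound 1 `CC(C)N1CCN(Cc2csc(N)c2C(=O)c2ccc(Cl)cc2)CC1`, -7.4%
compound 2 `Nc1scc(CN2CCN(c3ccc(Cl)cc3Cl)CC2)c1C(=O)c1ccc(Cl)cc1`, -74%
compound 3 `COc1ccc(N2CCN(Cc3csc(N)c3C(=O)c3ccc(Cl)cc3)CC2)cc1`, -52%

Compound 1 stands highest of the three, meaning the weakest effect, and its steps to compound 3 and to compound 2 are both beyond the scatter. Compound 4 `Nc1scc(CN2CCN(C3CCCCCC3)CC2)c1C(=O)c1ccc(Cl)cc1` differs from compound 1 in one place: cycloheptyl in place of isopropyl on an amine nitrogen in a ring. Two measured steps start from compound 1 and replace the same isopropyl group with a ring: a number 66.6 percentage points lower from compound 1 to compound 2 (beyond the scatter) and a number 44.6 percentage points lower from compound 1 to compound 3 (beyond the scatter), both large. Cycloheptyl is also a ring with more heavy atoms than isopropyl, but not an aromatic one, so the outcome is less certain. A lowering is therefore expected in this assay, a number 27.6 percentage points lower from compound 1 to compound 4 (beyond the scatter). For compound 4 the estimated value is -35%, with a range from -70% to 0%.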

Compound 4, a percentage reported as activity, at one concentration (the size of the read-out at that concentration, not a potency): -25%
Compound 4: the middle estimate sits 10 percentage points below what was measured; the measured number falls inside the stated range.
By their numbers in this assay, from the lowest: compound 2; then compound 3; then compound 4; then compound 1.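

In this assay, a ring without aromatic character on the amine nitrogen in a ring still gives a stronger effect than isopropyl (a number 17.6 percentage points lower from compound 1 to compound 4 (beyond the scatter)), so an aromatic ring is not required for a step beyond the scatter. Cycloheptyl nevertheless gives a weaker effect than either aromatic group (a number 27 percentage points higher from compound 3 to compound 4 (beyond the scatter); a number 49 percentage points higher from compound 2 to compound 4 (beyond the scatter)). Nothing available explains this order.

From the compounds shown here alone, it remains open whether ring size matters among non-aromatic rings, as a cyclopentyl group would test. Unsubstituted phenyl would show what the substituents on the aromatic rings contribute.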